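Changing the ring on the sulfonyl sulfur: an expectation

The source may report more compounds than this note shows. Statements on the series, on what has been measured and on what is new or still open speak of the compounds shown alone.

Of the compounds shown here, three have so far been tested in an assay on isolated protein for displacement of a labelled ligand from metabotropic glutamate receptor 5 (Homo sapiens), with a stated time of 60 min, tested at 1 uM; a higher number here means more inhibition at the concentration tested (going by the name of the read-out), a lower number less inhibition. Compound 1 `COc1cccc(S(=O)(=O)c2cnc3ccc(OC)cc3c2N2CCC(C)CC2)c1` gives 0%. Compound 2 `COc1ccc2ncc(S(=O)(=O)c3ccc(C)c(F)c3)c(N3CCC(C)CC3)c2c1` gives 73% in this assay. These two differ in one place only: 3-fluoro-4-methylphenyl in place of 3-methoxyphenyl on a sulfonyl sulfur. That exchange produced a number 73 percentage points higher from compound 1 to compound 2 (beyond the scatter). Compound 3 `COc1cccc(S(=O)(=O)c2cnc3cc(F)ccc3c2N2CCC(C)CC2)c1` gives 90% in this assay, the highest of the three numbers, and it differs from compound 1 in its core; the difference between the two cores is not broken down here.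

Compound 4 `Cc1ccc(S(=O)(=O)c2cnc3cc(F)ccc3c2N2CCC(C)CC2)cc1F` has not been measured. It carries the same exchange, now on the core of compound 3: 3-fluoro-4-methylphenyl in place of 3-methoxyphenyl on a sulfonyl sulfur. For the measured compounds named here, the surroundings of the changed group are described in the same words for both pairs, so this is the same change as the one from compound 1 to compound 2. Because compound 3 already gives 90%, the scale leaves little room for a rise of the earlier size, and a much smaller step is therefore expected: a number 4 percentage points higher from compound 3 to compound 4 (within the scatter). Compound 4 is estimated at 94%, with a likely range from 84% to 100%.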

Compound 4, a percentage reported as inhibition, at one concentration (the size of the read-out at that concentration, not a potency): 89%
Beside the measured number, compound 4's estimate is 5 percentage points above it, and the stated range covers the measured number.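

On the core of compound 3, putting 3-fluoro-4-methylphenyl in place of 3-methoxyphenyl on a sulfonyl sulfur gives a number 1 percentage points lower from compound 3 to compound 4 (within the scatter) in this assay, so the large rise seen on the core of compound 1 does not reappear. This change therefore cannot be counted as a fixed gain that carries from one core to another in this series, as the two steps show: the same change on two cores in this assay, a number 73 percentage points higher (beyond the scatter) from compound 1 to compound 2 and a number 1 percentage points lower (within the scatter) from compound 3 to compound 4, 74 percentage points apart, beyond the scatter of two such steps. They do not show why the steps differ, nor that the two groups are truly equal on this core, since compound 3 already gives 90% and a single reading this high on the scale could hide a difference in potency.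

As far as these compounds go, two cores are too few to tell how the change behaves on the shared scaffold in general, so its effect on further cores remains open. Also open, from the compounds shown here alone, is how other groups on the sulfonyl sulfur would behave, such as an unsubstituted phenyl or a ring carrying an amine or a carboxylic acid.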